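Taking one fluoro off compound 2

The compounds below may be only part of what the source reports. "The series", "measured", "known", "first", "only" and "open" are said of these compounds alone.

In an ADME assay on liver for metabolic stability, with Liver microsome (Rattus norvegicus) as the target, using microsomes and NADPH, with a stated time of 30 min, tested at 0.5 uM (on this read-out lower numbers stand for slow clearance and higher numbers for fast clearance), three compounds have been measured so far. Compound 1 `O=C1NCCN1CCOc1nn(-c2ccccc2F)c2ccc(F)cc12` gives 1380 mL/min/kg. Compound 2 `O=C1NCCN1CCOc1nn(-c2ccc(F)cc2F)c2ccc(F)cc12` gives 617 mL/min/kg, the lowest of the three. Compound 3 `O=C1C2CN(Cc3ccccc3)CC2CN1c1cccc2c1cnn2-c1ccccc1F`, built on a different core, gives 2850 mL/min/kg.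

The unmeasured compound 4 `O=C1NCCN1CCOc1nn(-c2ccc(F)cc2)c2ccc(F)cc12` differs from compound 2 in one place: hydrogen in place of fluoro on an aromatic carbon. Put simply, hydrogen stands in place of fluoro on an aromatic carbon, so 2,4-difluorophenyl becomes 4-fluorophenyl.

Within the data shown here, only one measured step bears on this change: a 2.2-fold lower number from compound 1 to compound 2 (0.35 log units; beyond the scatter). That modest step, beyond the scatter, also exchanged hydrogen and fluoro on this ring, but it added a fluoro and did so at a different carbon. Among the measured compounds shown here, compound 4 keeps the fluoro gained in that step and loses the one shared by compound 1 and compound 2. For the measured compounds named here, no measured pair shows what losing that fluoro does, so the earlier step cannot simply be run backwards. Compound 3 offers little guidance, since its core differs.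

The expected change is a 1.1-fold higher number from compound 2 to compound 4 (0.05 log units; within the scatter), an estimate that stays within the usual scatter. For compound 4 the estimated clearance is 700 mL/min/kg, with an expected range from 350 mL/min/kg to 1400 mL/min/kg.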

Compound 4, clearance: 217 mL/min/kg
Estimate against measurement, compound 4: 3.2-fold (0.51 log units) above, outside the stated range (below it).
By their numbers in this assay, from the lowest: compound 4; then compound 2; then compound 1; then compound 3.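

Among these compounds, the fluoro that sits ortho to a large group on this ring turns out to matter in this assay: putting hydrogen in its place gives a 2.8-fold lower number from compound 2 to compound 4 (0.45 log units; beyond the scatter), a drop that the earlier compounds could not reveal, since none of them lacked this fluoro. Comparing the two rings that carry a single fluoro, 4-fluorophenyl in place of 2-fluorophenyl gives a 6.4-fold lower number from compound 1 to compound 4 (0.80 log units; beyond the scatter), which places the three rings in the order 4-fluorophenyl, 2,4-difluorophenyl, 2-fluorophenyl from the lowest clearance to the highest, on the shared core of compound 1, compound 2 and compound 4. Nothing shown here measures why clearance changes with this fluoro, so the result stands as an observation without an explanation.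

The compounds shown leave open what a plain phenyl ring with no fluoro at all would give on this core, and whether a chloro or methyl group at the same place would behave like hydrogen or like fluoro. They also leave open whether this ring order would hold on a different core, such as that of compound 3.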